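Chloro removal on the fused ring in two thioamide-derived series

A few compounds are considered here, and "the series" means these few. Any claim that something is new, unique, unknown or untested is made for them only; others in the source may bear on it.

Measured so far:
compound 1, `O=c1c(C(=S)Nc2ccccc2)coc2cc(Cl)ccc12`, gives 63600 nM in a functional assay on A549 cells (Homo sapiens) for inhibition, read by sulforhodamine B assay, with a stated time of 48 h; on this read-out higher numbers stand for weaker inhibition and lower numbers for stronger inhibition.
compound 2, `O=c1c(C2N=C(c3ccccc3)SS2)coc2ccc(Cl)cc12`, gives 71300 nM in this assay.
compound 3, `O=c1c(C2N=C(c3ccccc3)SS2)coc2ccccc12`, gives > 100000 nM in this assay, which is a limit of the assay and not a number.

Compound 1 and compound 2 sit within the scatter of each other in this assay; the difference between their two cores is not broken down here. From compound 2 to compound 3 the change is hydrogen in place of chloro on an aromatic carbon, and it gives an at least 1.4-fold higher number from compound 2 to compound 3 (0.14 log units; that floor lies within the scatter), the result being shaped by the limit of > 100000 nM in this assay, at which 1 of the 3 values shown sits.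

Compound 4, `O=c1c(C(=S)Nc2ccccc2)coc2ccccc12`, is not yet measured. It differs from compound 1 by the same change, (hydrogen in place of chloro on an aromatic carbon). The analogous step from compound 2 to compound 3 ran to the limit. A step of about a 1.6-fold higher number from compound 1 to compound 4 (0.20 log units; within the scatter) is expected for compound 4, carrying it close to the limit. The estimate for compound 4 in this assay is 100000 nM, between 50000 nM and 250000 nM.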

Compound 4, half-maximal inhibitory concentration: 52800 nM
Beside the measured number, compound 4's estimate is 1.9-fold (0.28 log units) above it; the range from low to high includes it.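

On the core of compound 1, hydrogen in place of chloro gives a 1.2-fold lower number from compound 1 to compound 4 (0.08 log units; within the scatter) in this assay, so this step shows no effect beyond the scatter on this core. Set beside the same change on the core of compound 2, the comparison stands as follows: the same change on two cores in this assay, an at least 1.4-fold higher number (0.14 log units; that floor lies within the scatter) from compound 2 to compound 3 and a 1.2-fold lower number (0.08 log units; within the scatter) from compound 1 to compound 4; the limit leaves it open whether they differ. Compound 3 gives only a limit and not a number, so the notes cannot say whether the change carries from one core to the other or behaves differently on each: the limit of > 100000 nM in this assay, at which 1 of the 4 values shown sits.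

Still open, from the compounds shown here alone, is whether a group other than chloro on that aromatic carbon, such as fluoro, methoxy or an amine, would move the number in this assay beyond the scatter on either core.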